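Working Notes on Substituent Swaps in a Bile Acid Receptor Series

This account rests on a few compounds, and the source may have more. Where it says the series, first, only, none or still open, it means among the compounds named here.

Three compounds of the shared core have been run in an assay on HeLa cells with Bile acid receptor (Homo sapiens) as the target, read by a luciferase reporter, with a stated time of 24 h; on this read-out higher numbers stand for an effect only at larger amounts of compound and lower numbers for an effect already at smaller amounts. Compound 1 `CC(C)Oc1ccc(CNC(=O)c2ccc(C(C)(C)C)cc2)cc1` gives 170 nM. Compound 2 `CC(C)(C)c1ccc(C(=O)NCc2ccc(NS(C)(=O)=O)cc2)cc1` gives 44 nM. Compound 3 `CSc1ccc(CNC(=O)c2ccc(C(C)(C)C)cc2)cc1` gives 100 nM. On these three numbers compound 3 stands second highest: the step of a 1.7-fold lower number from compound 1 to compound 3 (0.23 log units; within the scatter) lies within the scatter, whereas the step of a 2.3-fold higher number from compound 2 to compound 3 (0.36 log units; beyond the scatter) lies beyond it.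

The next compound is compound 4 `CC(=O)Nc1ccc(CNC(=O)c2ccc(C(C)(C)C)cc2)cc1`, which differs from compound 3 in one place: acetamido in place of methylsulfanyl on an aromatic carbon. Among the measured compounds shown here, two measured steps bear on this change. The step of a 2.3-fold higher number from compound 2 to compound 3 (0.36 log units; beyond the scatter) shows the move from a group with one hydrogen-bond donor and one acceptor to methylsulfanyl, and the step of a 3.9-fold lower number from compound 1 to compound 2 (0.59 log units; beyond the scatter) shows the gain of such a group from a plain ether. Acetamido, as counted above, again brings one donor and one acceptor, so a modest move toward a lower number is expected rather than none, though the two steps on record are small and a result within the scatter cannot be excluded.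

Compound 4 is therefore expected to show the step of a 1.8-fold lower number from compound 3 to compound 4 (0.26 log units; within the scatter). The estimate for compound 4 in this assay is 55 nM, with a range from 25 nM to 130 nM.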

Compound 4, half-maximal effective concentration: 2900 nM
The estimate for compound 4 lay 53-fold (1.72 log units) below the measured number, outside the stated range (above it).
By their numbers in this assay, from the lowest: compound 2; then compounds 3 and 1 (each within the scatter of the next); then compound 4.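

The sharpest reading comes from the pair that differs only in what sits on the nitrogen on the aromatic ring: acetyl in place of methylsulfonyl gives a 66-fold higher number from compound 2 to compound 4 (1.82 log units; beyond the scatter) in this assay and shows that this nitrogen does not carry the lower number by itself, since the group attached to it matters a great deal. Acetamido also stands apart from the two groups without that nitrogen, with a 29-fold higher number from compound 3 to compound 4 (1.46 log units; beyond the scatter) and a 17-fold higher number from compound 1 to compound 4 (1.23 log units; beyond the scatter) as its steps, so among the four compounds this position accepts methylsulfanyl, isopropoxy and methanesulfonamido with far smaller differences, and acetamido alone gives a large rise. Nothing on hand explains the gap between the acetyl and methylsulfonyl groups on that nitrogen.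

The compounds shown leave open whether a free amine at this place would fall with compound 2 or with compound 4, and so whether the acetyl group or the methylsulfonyl group is the one that departs from the bare nitrogen. They also leave open how an ethylsulfonyl group or a longer acyl chain such as butyryl on the same nitrogen would read out.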